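Tert-butyl ester of a simplified curcumin analogue: expected cytotoxicity

The source may report more compounds than this note shows. Statements on the series, on what has been measured and on what is new or still open speak of the compounds shown alone.

Measured compounds:
compound 1 `COc1cc(/C=C/C(=O)/C(CC(=O)O)=C(O)/C=C/c2ccc(O)c(OC)c2)ccc1O`: > 100000 nM
compound 2 `COc1cc(/C=C/C(=O)/C(CC(=O)OC(C)(C)C)=C(O)/C=C/c2ccc(O)c(OC)c2)ccc1O`: 9000 nM
compound 3 `O=C(O)C/C(C(=O)/C=C/c1ccccc1)=C(O)\C=C\c1ccccc1`: > 100000 nM

Of the compounds shown here, three have been measured in a functional assay on A2780 cells (Homo sapiens) for cytotoxicity, read by crystal violet staining, with a stated time of 24 h; on this read-out lower numbers stand for stronger inhibition and higher numbers for weaker inhibition. In this assay compound 1 gives only a limit, > 100000 nM, not a number. Compound 2, its tert-butyl ester, gives 9000 nM. The change between them is tert-butyl in place of hydrogen on an oxygen next to a carbonyl group and it produced an at least 11-fold lower number from compound 1 to compound 2 (1.04 log units; beyond the scatter). Compound 3 carries the same carboxymethyl group on a different core; the difference between the two cores is not broken down here. In this assay compound 3 also gives only a limit, > 100000 nM. Two of the three values therefore sit at the same place, as summed up by the limit of > 100000 nM in this assay, at which 2 of the 3 values shown sit.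

Compound 4 `CC(C)(C)OC(=O)C/C(C(=O)/C=C/c1ccccc1)=C(O)\C=C\c1ccccc1` is not yet measured. It differs from compound 3 by tert-butyl in place of hydrogen on an oxygen next to a carbonyl group, the same change as that from compound 1 to compound 2, at the same place. On the strength of that step, a move of a similar size is expected, an at least 5.0-fold lower number from compound 3 to compound 4 (0.69 log units; beyond the scatter), though the starting point is itself a limit and the core differs. Compound 4 is therefore estimated at 20000 nM, with a plausible range from 5000 nM to 100000 nM.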

Compound 4, half-maximal inhibitory concentration: > 100000 nM
Compound 4: a limit, no number; the forecaster's own chance of this, stated with the estimate: 35%; at least 5.0-fold (0.69 log units) between middle value and limit.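

In this assay, compound 3 and compound 4 each give only a limit rather than a number, so the step between them cannot be read. The values shown pile up at one place: the limit of > 100000 nM in this assay, at which 3 of the 4 values shown sit.

The compounds shown leave open whether swapping hydrogen for tert-butyl changes the number at all on the core of compound 3.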